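This account rests on a few compounds, and the source may have more. Where it says the series, first, only, none or still open, it means among the compounds named here.

Measured so far in a functional assay on BGC-823 cells (Homo sapiens) for cytotoxicity, read by CCK-8 assay, with a stated time of 72 h; a higher number here means a weaker inhibitor, a lower number a stronger inhibitor: compound 1 `COc1ccccc1/C=c1/[nH]c(=O)/c(=C\c2ccccc2OC)n(C)c1=O` gives "not active" (no number reported); compound 2 `C=CCn1c(=O)/c(=C\c2cccc(F)c2)[nH]c(=O)/c1=C\c1ccccc1OC` gives 5600 nM; compound 3 `C=CCn1c(=O)/c(=C\c2ccccc2OC)[nH]c(=O)/c1=C\c1ccccc1OC` gives 13400 nM.

Compound 3 holds the highest of the two numbers reported in this assay; its nearest neighbour is compound 2, and the step of a 2.4-fold higher number from compound 2 to compound 3 (0.38 log units; beyond the scatter) separates them beyond the scatter. Compound 1 returned no number.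

Compound 4 `C=CCn1c(=O)/c(=C\c2cc(F)ccc2C)[nH]c(=O)/c1=C\c1ccccc1OC` differs from compound 3 by 5-fluoro-2-methylphenyl in place of 2-methoxyphenyl on a double-bonded chain carbon bound to an aromatic carbon. The one measured step bearing on this exchange is a 2.4-fold higher number from compound 2 to compound 3 (0.38 log units; beyond the scatter), where a fluorophenyl on the double-bonded chain carbon bound to an aromatic carbon gave the lower number; the incoming group here carries a fluorine together with a methyl, for which no precedent exists among these compounds. Read in reverse, a modest downward step in this assay is expected for compound 4. Compound 4 is estimated at 7000 nM in this assay, range 2500 nM to 25000 nM, a step of a 1.9-fold lower number from compound 3 to compound 4 (0.28 log units; within the scatter).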

Compound 4, half-maximal inhibitory concentration: 1600 nM
Compound 4: middle estimate off by 4.4-fold (0.64 log units), on the high side, and the stated range ends above it.
By their numbers in this assay, from the lowest: compound 4; then compound 2; then compound 3.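

In this assay, for the compounds shown here, the position on a double-bonded chain carbon bound to an aromatic carbon responds strongly to the ring it carries: 5-fluoro-2-methylphenyl in place of 2-methoxyphenyl gives an 8.4-fold lower number from compound 3 to compound 4 (0.92 log units; beyond the scatter), the largest step so far. Methyl in place of hydrogen on an aromatic carbon also counts, with a 3.5-fold lower number from compound 2 to compound 4 (0.54 log units; beyond the scatter), so this ring takes more than a lone fluorine and the number still falls. Nothing measured here explains either step.

The compounds shown leave open what the fluorine adds to the methyl. Also open, going by these compounds, is whether an amine or a carboxylic acid on this ring would keep the lower number.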